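The compounds below may be only part of what the source reports. "The series", "measured", "known", "first", "only" and "open" are said of these compounds alone.

Compounds measured in an ADME assay on CHO cells (Cricetulus griseus) for cytotoxicity, read by LDH release; on this read-out higher numbers stand for weaker inhibition and lower numbers for stronger inhibition:
- compound 1 `CC(Nc1ccc(Cl)cc1Cl)C(=O)NCc1ccc(F)cc1`: > 100000 nM
- compound 2 `CC(Oc1ccc(Cl)cc1Cl)C(=O)N[C@H](C)c1ccc(F)cc1`: 97000 nM
- compound 3 `CCC(NC(=O)C(C)Oc1ccc(Cl)cc1Cl)c1ccc(F)cc1`: > 100000 nM

Compound 3 gives > 100000 nM, which is a limit of the assay and not a number. Compound 1 gives > 100000 nM, which is likewise a limit. The series therefore sits at the top of the range, with the limit of > 100000 nM in this assay, at which 2 of the 3 values shown sit. Among the compounds with values here, compound 2 is the only one with a true number, at 97000 nM.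

Compound 4 `CC(Oc1ccc(Cl)cc1Cl)C(=O)NC(CO)c1ccc(F)cc1` has not yet been measured. It differs from compound 3 by hydroxy in place of methyl on a saturated chain carbon, two bonds along the chain from an amide-type nitrogen and an aromatic carbon, which reads as ethyl to hydroxymethyl.

No measured step sizes this change. In this assay, no step beyond the usual scatter is expected, in either direction, given that compound 2 reads 97000 nM. The expected change is a number no higher from compound 3 to compound 4 (the limit leaves the size open). For compound 4 the estimated value is 100000 nM, with an expected range of 50000 nM to 200000 nM.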

Compound 4, half-maximal inhibitory concentration: 18000 nM
Compound 4: middle estimate off by 5.6-fold (0.74 log units), on the high side; measured number outside the range, below it.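

In this assay, hydroxy in place of methyl on a saturated chain carbon, two bonds along the chain from an amide-type nitrogen and an aromatic carbon, gives an at least 5.5-fold lower number from compound 3 to compound 4 (0.74 log units; beyond the scatter). Within the data shown here, this position therefore responds to the change from ethyl to hydroxymethyl, whereas the earlier compounds alone gave no step from which to judge it. The true size of the step stays unknown, and only its lower bound can be stated, because compound 3 stands at a limit of the assay and not at a number: the limit of > 100000 nM in this assay, at which 2 of the 4 values shown sit.

The compounds shown leave open whether an amine, a carboxylic acid or a methoxy group at this place would also lower the number. They also leave open whether a longer chain carrying the hydroxy would keep the step.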